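Bromo-to-cyano exchange in a cytotoxicity series: working notes

The source may hold more compounds than are shown below. What is called first, only, known or untested is meant among the compounds shown, and "the series" means these compounds.

Measured compounds in a functional assay on SMMC-7721 cells (Homo sapiens) for cytotoxicity, read by MTT assay, with a stated time of 24 h; a higher number here means a weaker inhibitor, a lower number a stronger inhibitor:
compound 1 `O=C1/C(=C/c2ccccc2F)CN(S(=O)(=O)c2ccc(Br)cc2)C/C1=C\c1ccccc1F`: 5200 nM
compound 2 `N#Cc1ccc(S(=O)(=O)N2C/C(=C\c3ccccc3F)C(=O)/C(=C/c3ccccc3F)C2)cc1`: 14600 nM
compound 3 `O=C1/C(=C/c2ccc(F)cc2)CN(S(=O)(=O)c2ccc(Br)cc2)C/C1=C\c1ccc(F)cc1`: 11500 nM

Compound 1 and compound 2 differ by one change, (cyano in place of bromo on an aromatic carbon), and this change gave a 2.8-fold higher number from compound 1 to compound 2 (0.45 log units; beyond the scatter) in this assay. Compound 3 carries the same bromo group as compound 1 on a different core; the difference between the two cores is not broken down here. Its value sits near that of compound 2 and beyond the scatter from that of compound 1.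

Compound 4 `N#Cc1ccc(S(=O)(=O)N2C/C(=C\c3ccc(F)cc3)C(=O)/C(=C/c3ccc(F)cc3)C2)cc1` is not yet measured. It relates to compound 3 as compound 2 relates to compound 1: cyano in place of bromo on an aromatic carbon, at a place described in the same words, so the change is the same one. Among the compounds with values here, the only precedent for this change is the step from compound 1 to compound 2, and the expectation for compound 4 rests on that single step. On that basis the step from compound 3 to compound 4 in this assay is expected to be a 2.8-fold higher number from compound 3 to compound 4 (0.44 log units; beyond the scatter), of a similar size to the earlier one. Compound 4 is therefore estimated at 32000 nM, between 15000 nM and 70000 nM.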

Compound 4, half-maximal inhibitory concentration: 15000 nM
Compound 4: middle estimate off by 2.1-fold (0.33 log units), on the high side; low and high end bracket the measured number.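

In this assay, the exchange of bromo for cyano on the core of compound 3 gave a 1.3-fold higher number from compound 3 to compound 4 (0.12 log units; within the scatter), a step that cannot be told apart from repeat measurement. Set beside the step on the core of compound 1, it does not differ by more than two such steps can: the same change on two cores in this assay, a 2.8-fold higher number (0.45 log units; beyond the scatter) from compound 1 to compound 2 and a 1.3-fold higher number (0.12 log units; within the scatter) from compound 3 to compound 4, 2.2-fold (0.33 log units) apart, within the scatter of two such steps. Within the data shown here, the two cores are therefore compatible with a single size for this change, but two pairs cannot establish one, only the step on the core of compound 1 lies beyond the scatter on its own, and nothing here shows how the change would carry to a third core.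

The compounds shown leave open how an amine, a methoxy group or a carboxylic acid would compare with bromo and cyano at the same place on the 4-bromophenyl ring. Also open, as far as these compounds go, is whether the step would keep its size on a core carrying chloro or methoxy groups instead of the fluoro groups.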